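A few compounds are considered here, and "the series" means these few. Any claim that something is new, unique, unknown or untested is made for them only; others in the source may bear on it.

Measured so far:
compound 1 `Cc1ccccc1-c1cncc(OC[C@@H]2CCCN2C)c1` gives 1.1 nM
compound 2 `CN1CCC[C@H]1COc1cncc(-c2ccc3ccccc3c2)c1` gives 0.33 nM
compound 3 `CN1CCC[C@H]1COc1cncc(-c2cc3ccccc3o2)c1` gives 0.15 nM

All three share a core carrying a basic ring on one side and an aromatic group on the other, and all were tested in an assay on membranes from brain for binding affinity to Neuronal acetylcholine receptor; alpha4/beta2 (Rattus norvegicus); on this read-out higher numbers stand for weaker inhibition and lower numbers for stronger inhibition. Compound 1 stands at the highest number of the three, with compound 2 and compound 3 both reaching lower numbers, each beyond the usual scatter. Compound 4 `CN1CCC[C@H]1COc1cncc(-c2cncnc2)c1` has not been measured; it differs from compound 1 by pyrimidin-5-yl in place of 2-methylphenyl on an aromatic carbon. Going by the values given here, no measured pair shows this kind of change, so the direction is uncertain. A modest step toward a higher number is expected in this assay, possibly within the scatter. Compound 4 is estimated at 2.5 nM, with a range of 0.6 nM to 10 nM, which means an expected step of a 2.3-fold higher number from compound 1 to compound 4 (0.36 log units; beyond the scatter).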

Compound 4, inhibition constant: 0.37 nM
Estimate against measurement, compound 4: 6.8-fold (0.83 log units) above, outside the stated range (below it).
By their numbers in this assay, from the lowest: compound 3; then compounds 2 and 4 (each within the scatter of the next); then compound 1.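

In this assay, the aromatic carbon two atoms from the ring nitrogen accepts pyrimidin-5-yl in place of 2-methylphenyl, and the swap gives a 3.0-fold lower number from compound 1 to compound 4 (0.47 log units; beyond the scatter) on the shared core. An all-carbon ring is therefore not needed at this position for a low number, and a ring with two hetero atoms serves there too. Nothing available explains this step. From the compounds shown here alone, the change removes the methyl and adds ring nitrogens together, so their separate shares stay open, as does what an unsubstituted phenyl or a pyridin-3-yl group would give here.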